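The compounds below may be only part of what the source reports. "The series", "measured", "known", "first", "only" and "open" are said of these compounds alone.

Measured compounds:
- compound 1, `NC(=S)/N=C1/C=C[C@H]2CO[C@@H]1O2`: > 1000000 nM
- compound 2, `NC(=S)/N=C1/CC[C@H]2CO[C@@H]1O2`: > 1000000 nM
- compound 3, `CC(=O)O[C@@H]1[C@@H](OC(C)=O)[C@H](S[C@@H]2C/C(=N/C(N)=S)[C@@H]3OC[C@H]2O3)OC[C@@H]1OC(C)=O`: 826000 nM

In a functional assay on A2780 cells (Homo sapiens) for cytotoxicity, read by CCK-8 assay, with a stated time of 72 h (a lower number here means a stronger inhibitor, a higher number a weaker inhibitor), compound 1 reaches only a limit of the assay, > 1000000 nM. In this assay compound 2 likewise gives only a limit, > 1000000 nM. Going by the values given here, compound 3 is the one compound with a number in this assay, 826000 nM, and it sits apart from the limit of > 1000000 nM in this assay, at which 2 of the 3 values shown sit, only in that it is a number at all; it is a weak inhibitor.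

Compound 4, `CC(=O)OC[C@H]1O[C@@H](S[C@@H]2C/C(=N/C(N)=S)[C@@H]3OC[C@H]2O3)[C@H](OC(C)=O)[C@@H](OC(C)=O)[C@H]1OC(C)=O`, is compound 3 with acetoxymethyl in place of hydrogen on a saturated ring carbon. Among the compounds with values here, no measured pair shows such a step, so the expectation for compound 4 rests on compound 3 alone, and the step is expected to stay within the scatter, a 1.1-fold higher number from compound 3 to compound 4 (0.04 log units; within the scatter). Compound 4 is therefore estimated at 900000 nM in this assay, within 300000 nM to 3000000 nM.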

Compound 4, half-maximal inhibitory concentration: 846000 nM
Estimate against measurement, compound 4: 1.1-fold (0.03 log units) above; the range from low to high includes it.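

Putting acetoxymethyl in place of hydrogen on a saturated ring carbon, next to the ring oxygen, leaves compound 3 and compound 4 indistinguishable in this assay: a 1.0-fold higher number from compound 3 to compound 4 (0.01 log units; within the scatter). Going by these compounds alone, this is the first step between measured compounds that can be read, and it shows that this position accepts the added group without a measurable difference. Both compounds remain weak inhibitors, with numbers in the same range as the assay's limit: the limit of > 1000000 nM in this assay, at which 2 of the 4 values shown sit.

As far as these compounds go, whether an amine or a carboxylic acid on this ring carbon would give a different reading remains open. So does whether any change here can produce a strong inhibitor.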